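The source may report more compounds than this note shows. Statements on the series, on what has been measured and on what is new or still open speak of the compounds shown alone.

In a functional assay on KB cells (Homo sapiens) for antiproliferative activity, read by MTT assay, with a stated time of 72 h (a higher number here means a weaker inhibitor, a lower number a stronger inhibitor), compound 1 `CCOC(=O)c1cc(-c2cc(OC)c(OC)c(OC)c2)c(-c2ccc(OC)cc2)s1` gives 13200 nM and compound 2 `CCOC(=O)c1cc(-c2cc(OC)c(OC)c(OC)c2)c(-c2ccc(OC)c([N+](=O)[O-])c2)s1` gives 15800 nM. These two numbers cannot be told apart, so compound 2 stands level with compound 1. Compound 3 `CCOC(=O)c1cc(-c2cc(OC)c(OC)c(OC)c2)c(-c2ccc(OC)c(OCc3ccccc3)c2)s1` differs from compound 2 at one place: benzyloxy in place of nitro on an aromatic carbon. Benzyloxy takes the place of nitro on an aromatic carbon, ortho to a methoxy group. Among the compounds with values here, only one measured step bears on this carbon: a 1.2-fold higher number from compound 1 to compound 2 (0.08 log units; within the scatter). Within the data shown here, that step replaced hydrogen with nitro and stayed small, but no measured compound carries benzyloxy, so it is only a weak guide. No shift beyond the scatter is therefore expected in either direction, and the range must stay wide. In this assay, the expected step is a 1.1-fold lower number from compound 2 to compound 3 (0.02 log units; within the scatter). Compound 3 is estimated at 15000 nM, with an expected range of 6000 nM to 40000 nM.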

Compound 3, half-maximal inhibitory concentration: > 100000 nM
Compound 3 gave a limit, no number (the forecaster's own chance of this, stated with the estimate: 15%); middle value at least 6.6-fold (0.82 log units) from the limit.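

In this assay, this carbon, ortho to a methoxy group, proves sensitive to what it carries, which the small hydrogen-to-nitro swap did not reveal: benzyloxy gives an at least 6.3-fold higher number from compound 2 to compound 3 (0.80 log units; beyond the scatter) and also an at least 7.5-fold higher number from compound 1 to compound 3 (0.87 log units; beyond the scatter). Compound 3 gave a limit of the assay and not a number, so how far its activity falls remains unknown: the limit of > 100000 nM in this assay, at which 1 of the 3 values shown sits. Among these compounds, then, the group that enters with 8 heavy atoms and its own six-membered aromatic ring goes with a clear drop in activity, whereas nitro, with 3 heavy atoms, does not.

The compounds shown do not separate the role of the added ring from that of the oxygen link. On these data alone, it also remains open how a smaller group on this carbon, such as a hydroxyl, an ethoxy or an amine, would read in this assay.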